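The compounds below may be only part of what the source reports. "The series", "measured", "known", "first", "only" and "open" are said of these compounds alone.

Measured in an ADME assay on HEK293 cells (Homo sapiens) for cytotoxicity, with a stated time of 72 h; a higher number here means that more compound is needed for the effect, a lower number that less compound is needed:
Compound 1 `CSc1ccc(NC(=O)Nc2cc(C)nc3ccccc23)cc1`: 24000 nM
Compound 2 `Cc1cc(NC(=O)Nc2ccc(N(C)C)cc2)c2ccccc2n1`: > 25000 nM

The entry for compound 2 is a limit of the assay and not a number, so its position is given only by the limit of > 25000 nM in this assay, at which 1 of the 2 values shown sits. Compound 3 `Cc1cc(NC(=O)Nc2ccc(OC(F)(F)F)cc2)c2ccccc2n1` keeps the shared core and has trifluoromethoxy in place of dimethylamino on an aromatic carbon. Among the compounds with values here, one measured step bears on this change, as it alters the same place: dimethylamino in place of methylsulfanyl gave an at least 1.0-fold higher number from compound 1 to compound 2 (0.01 log units; that floor lies within the scatter). That step shows no change beyond the scatter, but it gives only a floor and involves a different incoming group. No clear shift is therefore expected in this assay, although a modest fall in the number remains possible. The expected step is an at least 1.2-fold lower number from compound 2 to compound 3 (0.09 log units; that floor lies within the scatter). For compound 3 the estimated value is 20000 nM, with an expected range from 8000 nM to 35000 nM.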

Compound 3, half-maximal effective concentration: 14000 nM
Compound 3: the middle estimate sits 1.4-fold (0.15 log units) above what was measured; measured number inside the range.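

In this assay, trifluoromethoxy in place of methylsulfanyl on this aromatic carbon gives a 1.7-fold lower number from compound 1 to compound 3 (0.23 log units; within the scatter), so a second exact number at this position does not separate from the first. Trifluoromethoxy in place of dimethylamino gives an at least 1.7-fold lower number from compound 2 to compound 3 (0.25 log units; that floor lies within the scatter), which adds only a floor for this change. Compound 2 has a limit of the assay and not a number, so the true size of that step stays unfixed: the limit of > 25000 nM in this assay, at which 1 of the 3 values shown sits.

Going by these compounds, how far dimethylamino truly stands from trifluoromethoxy and methylsulfanyl therefore remains open. Also open, on these data alone, is whether any other group at this position, such as a carboxylic acid, a primary amine or a longer alkyl chain, would move the number in this assay beyond the scatter.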